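A few compounds are considered here, and "the series" means these few. Any claim that something is new, unique, unknown or untested is made for them only; others in the source may bear on it.

Measured compounds in a functional assay on UACC-62 cells (Homo sapiens) for cytotoxicity, read by sulforhodamine B assay, with a stated time of 48 h; a higher number here means a weaker inhibitor of growth, a lower number a stronger inhibitor of growth:

compound 1 `Nc1nc(Cl)c2ncn(Cc3ccc(CCl)cc3)c2n1`: 2240 nM
compound 2 `ClCc1cccc(Cn2cnc3c(Cl)nc(Cl)nc32)c1`: 1860 nM
compound 3 `ClCc1ccc(Cn2cnc3c(Cl)nc(Cl)nc32)cc1`: 2040 nM

All three measured compounds give numbers in this assay that sit within the usual scatter of one another, so no order can be drawn among them. Compound 4 `Nc1nc(Cl)c2ncn(Cc3cccc(CCl)c3)c2n1` has not yet been measured.

One structural change recurs in two pairs of compounds: amino in place of chloro on an aromatic carbon. In the measured pair it runs from compound 3 to compound 1, and there the result was a 1.1-fold higher number from compound 3 to compound 1 (0.04 log units; within the scatter). The place of the change reads the same word for word in both pairs, so the change from compound 2 to compound 4 is the same change, not merely the same kind. Among the compounds with values here, compound 2 and compound 3 share the same atoms joined differently; the difference between the two cores is not broken down here, and what is known of it is only that their two values in this assay lie within the scatter of each other.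

With one measured example of this change, and that example within the scatter, the expectation for compound 4 rests on a flat step: the number for compound 4 is expected to be close to that of compound 2, with the expected step being a 1.1-fold higher number from compound 2 to compound 4 (0.04 log units; within the scatter), because compound 3 to compound 1 gave a 1.1-fold higher number from compound 3 to compound 1 (0.04 log units; within the scatter). Compound 4 is therefore estimated at 2050 nM in this assay, with a range from 1000 nM to 4200 nM, the width of the range reflecting that a single earlier step carries little weight.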

Compound 4, concentration for 50% growth inhibition: 2090 nM
Compound 4: middle estimate off by 1.0-fold (0.01 log units), on the low side; the range from low to high includes it.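

In this assay amino in place of chloro on an aromatic carbon, between two ring nitrogen atoms, gives a 1.1-fold higher number from compound 2 to compound 4 (0.05 log units; within the scatter) and the step reads alike on the two cores: the same change on two cores in this assay, a 1.1-fold higher number (0.04 log units; within the scatter) from compound 3 to compound 1 and a 1.1-fold higher number (0.05 log units; within the scatter) from compound 2 to compound 4, 1.0-fold (0.01 log units) apart, within the scatter of two such steps. Within these two pairs, then, the change carries from one core to the other as a flat step, and in neither pair does it move the number beyond the scatter. This does not show that the change would stay flat on a core outside these four compounds or in another assay, and two flat steps give no reason why the number holds.

Still open, as far as these compounds go, is whether a methoxy group or a dimethylamino group on that same aromatic carbon would read as flat as amino does. All four compounds also carry the chloromethyl group, so what a plain methyl or a hydroxymethyl group in its place would give in this assay remains an open question.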